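Pyridinyl in Place of Fluorophenyl on the Benzylic Arm

A few compounds are considered here, and "the series" means these few. Any claim that something is new, unique, unknown or untested is made for them only; others in the source may bear on it.

Compound 2 `CCN(Cc1ccc(F)cc1)c1cccc(C(=O)N2CCc3ccc(OS(N)(=O)=O)cc3C2)c1` gives 66.5% in an assay on HEK293 cells for inhibition of Steryl-sulfatase (Homo sapiens), tested at 1 uM (a lower number here means a weaker effect, a higher number a stronger effect of the compound at the concentration tested), the second highest of the three values shown. Within the data shown here, compound 1 `CCN(Cc1cccnc1)c1ccc(C(=O)N2CCc3ccc(OS(N)(=O)=O)cc3C2)cc1` gives 85.2% and compound 3 `CN(CCN1CCCCC1)c1ccc(C(=O)N2CCc3ccc(OS(N)(=O)=O)cc3C2)cc1` gives 26.8%; the only measured step, a number 58.4 percentage points lower from compound 1 to compound 3 (beyond the scatter), concerns a different exchange and does not bear on the present one. Compound 4 `CCN(Cc1cccnc1)c1cccc(C(=O)N2CCc3ccc(OS(N)(=O)=O)cc3C2)c1` differs from compound 2 by pyridin-3-yl in place of 4-fluorophenyl on a saturated chain carbon bound to a nitrogen on an aromatic ring. Among the measured compounds shown here, no measured step covers this exchange, so its size in this assay cannot be read from the data; compound 1 carries the same (pyridin-3-yl)methyl group and shows the highest value, but the rest of compound 1 differs from compound 4. The step of a number 1.5 percentage points higher from compound 2 to compound 4 (within the scatter) is therefore expected to stay within the scatter. The estimate for compound 4 is 68%, in the range 50% to 85%.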

Compound 4, a percentage reported as inhibition, at one concentration (the size of the read-out at that concentration, not a potency): 33.5%
For compound 4 the middle estimate is 34.5 percentage points above the measured one, outside the stated range (below it).
By their numbers in this assay, from the lowest: compounds 3 and 4 (each within the scatter of the next); then compound 2; then compound 1.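

Pyridin-3-yl in place of 4-fluorophenyl on a saturated chain carbon bound to a nitrogen on an aromatic ring gives a number 33 percentage points lower from compound 2 to compound 4 (beyond the scatter) in this assay and so is no neutral exchange at this position. Compound 4 carries the same (pyridin-3-yl)methyl group as compound 1, so that group alone does not ensure a high value across these cores. Nothing measured here bears on the reason for this step.

The compounds shown leave open whether phenyl or pyridin-4-yl at this place would keep the value of compound 2. They also leave open how 4-fluorophenyl would behave on the core of compound 1.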